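A few compounds are considered here, and "the series" means these few. Any claim that something is new, unique, unknown or untested is made for them only; others in the source may bear on it.

Compound 1 `O=C(O)C1=Cc2ccccc2OC1(OCc1cc(-c2ccc(F)cc2)no1)C(F)(F)F` gives 64200 nM in a functional assay on MCF7 cells (Homo sapiens) for inhibition, read by MTT assay, with a stated time of 24 h; on this read-out higher numbers stand for weaker inhibition and lower numbers for stronger inhibition.
Compound 2 `CCOC(=O)C1=Cc2ccccc2OC1(OCc1cn(CC(=O)Nc2ccccc2Br)nn1)C(F)(F)F` gives > 150000 nM, which is a limit of the assay and not a number.
Compound 3 `CCOC(=O)C1=Cc2ccccc2OC1(OCc1cn(-c2ccccc2)nn1)C(F)(F)F` gives > 150000 nM, again a limit and not a number.

Within the data shown here, compound 1 stands as the only compound of the three with a measured number in this assay; the other two sit at the limit of > 150000 nM in this assay, at which 2 of the 3 values shown sit. The change from compound 2 to compound 3, phenyl in place of ((2-bromophenyl)carbamoyl)methyl on an aromatic nitrogen, gives a step that the two limits leave unreadable from compound 2 to compound 3, so it teaches nothing about size.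

Compound 4 `COc1ccc(-c2cc(COC3(C(F)(F)F)Oc4ccccc4C=C3C(=O)O)on2)cc1` differs from compound 1 by methoxy in place of fluoro on an aromatic carbon. Among the measured compounds shown here, no measured step touches this change, and the one step that exists lies between two limits. The expectation for the step from compound 1 to compound 4 is therefore a 1.1-fold lower number from compound 1 to compound 4 (0.03 log units; within the scatter), a move not clearly beyond the scatter in either direction, with wide uncertainty. Compound 4 is thus estimated at 60000 nM, in a range from 20000 nM to 150000 nM.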

Compound 4, half-maximal inhibitory concentration: 35200 nM
Estimate against measurement, compound 4: 1.7-fold (0.23 log units) above; the range from low to high includes it.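

In this assay, going from 4-fluorophenyl to 4-methoxyphenyl gives a 1.8-fold lower number from compound 1 to compound 4 (0.26 log units; within the scatter), so this position, on a six-membered aromatic ring of carbon only and para to a large group, accepts methoxy in place of fluoro with no shift that stands clear of the usual scatter. Among these compounds, this is the first step in the set that can be read as a size, with a measured number at both ends instead of a limit. Nothing measured here explains why these two compounds read alike.

Going by these compounds, whether an amine or a longer chain such as butoxy at this position would move the number beyond the scatter remains open. The step between compound 2 and compound 3 cannot be read, since both of their values are limits of the assay and not numbers.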